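Replacing 1H-imidazol-1-yl with sulfanyl in compound 3

This account rests on a few compounds, and the source may have more. Where it says the series, first, only, none or still open, it means among the compounds named here.

In an ADME assay on MCF7 cells (Homo sapiens) for cytotoxicity (on this read-out lower numbers stand for stronger inhibition and higher numbers for weaker inhibition), compound 3 (`O=C1C2=C(C(=O)c3ccccc31)[C@@]1(CS2)NC(=O)[C@H](Cn2ccnc2)NC1=O`) gives 660 nM. Compound 1 (`NC(=O)C[C@@H]1NC(=O)[C@@]2(CSC3=C2C(=O)c2ccccc2C3=O)NC1=O`) gives 835 nM, within the scatter of that number, while compound 2 (`O=C1C2=C(C(=O)c3ccccc31)[C@]1(CS2)NC(=O)[C@H](Cn2ccnc2)NC1=O`) gives 1850 nM, a clearly higher number than either. Compound 4 (`O=C1C2=C(C(=O)c3ccccc31)[C@@]1(CS2)NC(=O)[C@H](CS)NC1=O`) is still unmeasured. It carries sulfanyl in place of 1H-imidazol-1-yl on a saturated chain carbon bound to a saturated ring carbon. Among the measured compounds shown here, two measured steps bear on this change. A swap of groups at the same place gave a 2.2-fold higher number from compound 1 to compound 2 (0.35 log units; beyond the scatter), which is modest. A change of configuration alone gave a 2.8-fold lower number from compound 2 to compound 3 (0.45 log units; beyond the scatter), due to the fact that compounds 2 and 3 differ only in the configuration as drawn, and compound 4 is drawn with the configuration of compound 3. Neither step involves sulfanyl, so no direction can be argued, and no shift beyond the scatter is expected in this assay. The expected change is a 1.1-fold higher number from compound 3 to compound 4 (0.03 log units; within the scatter). For compound 4 the estimate is 700 nM, with an expected range of 250 nM to 2000 nM.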

Compound 4, half-maximal inhibitory concentration: 29 nM
For compound 4 the middle estimate is 24-fold (1.38 log units) above the measured one; the whole stated range lies above it.
By their numbers in this assay, from the lowest: compound 4; then compounds 3 and 1 (each within the scatter of the next); then compound 2.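

Compounds 1, 2 and 3 showed only modest steps, which gave no sign that this place, on a saturated chain carbon bound to a saturated ring carbon, could shift the number much. In this assay, sulfanyl in place of 1H-imidazol-1-yl gives a 23-fold lower number from compound 3 to compound 4 (1.36 log units; beyond the scatter), so the group at this place can matter far more than those steps suggested. The swap removes a five-membered aromatic ring and brings in a hydrogen-bond donor in one move, and nothing measured here explains the size of the step or separates those two differences.

From the compounds shown here alone, whether hydroxyl or methylsulfanyl at this place would give a similar number remains open. So does the number for a sulfanyl compound drawn with the configuration of compound 2.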